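Swapping Ethyl for Ethoxy on the Side Chain

This account rests on a few compounds, and the source may have more. Where it says the series, first, only, none or still open, it means among the compounds named here.

Compound 1 `CC#CCOc1c(Cl)cc(N/C=N/OCC)cc1Cl` — a physicochemical assay for lipophilicity, measured as octanol-water partition; on this read-out lower numbers stand for lower lipophilicity and higher numbers for higher lipophilicity: 4
Compound 2 `C#CCc1c(Cl)cc(N/C=N/OCCC)cc1Cl` — this assay : 4

Of the compounds shown here, two share a common core and have been measured so far. In this assay compound 1 gives 4, and compound 2 gives 4. At the digits reported the two values are level, and the gap between them lies within the scatter of repeated measurements, so neither can be called the more lipophilic of the pair.

Compound 3 `C#CCc1c(Cl)cc(N/C=N/OCOCC)cc1Cl` has not yet been measured in this assay. It differs from compound 2 in one place: ethoxy in place of ethyl on a saturated chain carbon bound to an oxygen. For the measured compounds named here, nothing among the measured compounds shows the effect of this particular exchange, so no measured step can be quoted for it. An additional oxygen entering a chain of this kind is a change that commonly moves this read-out toward lower values, by an amount that is expected to lie beyond the scatter.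

Starting from compound 2, the step expected for compound 3 is a number 0.70 log units lower from compound 2 to compound 3 (beyond the scatter). Compound 3 is therefore estimated at 3.3, with a range from 2.8 to 3.8.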

Compound 3, partition coefficient: 3.5
For compound 3 the middle estimate is 0.20 log units below the measured one; measured number inside the range.
By their numbers in this assay, from the lowest: compound 3; then compounds 1 and 2 (each within the scatter of the next).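

For the compounds shown here, this pair gives the first measured step for this change: ethoxy in place of ethyl, on a saturated chain carbon bound to an oxygen, gives in this assay a number 0.50 log units lower from compound 2 to compound 3 (beyond the scatter) and so shows that this position of the side chain can register a change of this kind. Going by these compounds alone, compound 1 and compound 2 differ in more than one place, so their level values could not show what this single exchange does, and the new pair isolates it with only one group changed. No measurement at hand speaks to the cause of this step.

One exchange at one position cannot show whether the same step would appear if ethoxy replaced ethyl on the side chain of compound 1, where other parts of the molecule differ. It also leaves open how this assay would respond to a different group at this place, such as an amine, a carboxylic acid or a longer chain containing the same oxygen.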